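This account rests on a few compounds, and the source may have more. Where it says the series, first, only, none or still open, it means among the compounds named here.

Measured so far in a functional assay on MCF7 cells (Homo sapiens) for antiproliferative activity; a higher number here means a weaker inhibitor, a lower number a stronger inhibitor:
- compound 1 `CCCCCn1c(Cc2cc(OC)c(OC)c(OC)c2)nc2c(N)ncnc21` gives 61700 nM
- compound 2 `COc1cc(Cc2nc3c(N)ncnc3n2CC(C)C)cc(OC)c1OC` gives 97700 nM
- compound 3 `CCC(C)Cn1c(Cc2cc(OC)c(OC)c(OC)c2)nc2c(N)ncnc21` gives 61700 nM

All three share one core and differ only in the saturated chain on the aromatic nitrogen. Compound 3 stands level with compound 1, and the two together hold the lowest numbers of the three, though every gap among them sits inside the scatter: a 1.6-fold higher number from compound 1 to compound 2 (0.20 log units; within the scatter), no change at the digits printed from compound 1 to compound 3 (within the scatter), a 1.6-fold lower number from compound 2 to compound 3 (0.20 log units; within the scatter). Nothing in this set therefore separates one chain from another.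

Compound 4 `C/C=C/Cn1c(Cc2cc(OC)c(OC)c(OC)c2)nc2c(N)ncnc21` is the next member and has not yet been measured in this assay. It differs from compound 3 in this way: prop-1-en-1-yl in place of sec-butyl on a saturated chain carbon bound to an aromatic nitrogen. A double bond outside aromatic rings now enters the chain and one carbon leaves it. The three measured steps all concern the same place on the core, and each of them stayed within the scatter, so the chain has so far been a silent position. On that basis the expected step from compound 3 to compound 4 is none beyond the scatter, a 1.1-fold higher number from compound 3 to compound 4 (0.02 log units; within the scatter). The number expected for compound 4 is 65000 nM, with a range from 25000 nM to 160000 nM.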

Compound 4, half-maximal inhibitory concentration: 51300 nM
For compound 4 the middle estimate is 1.3-fold (0.10 log units) above the measured one; low and high end bracket the measured number.
By their numbers in this assay, from the lowest: compounds 4, 1, 3 and 2 (each within the scatter of the next).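

In this assay, the steps of a 1.2-fold lower number from compound 3 to compound 4 (0.08 log units; within the scatter) and a 1.2-fold lower number from compound 1 to compound 4 (0.08 log units; within the scatter) and a 1.9-fold lower number from compound 2 to compound 4 (0.28 log units; within the scatter) all lie within the scatter, so prop-1-en-1-yl on a saturated chain carbon bound to an aromatic nitrogen cannot be told apart from sec-butyl, butyl or isopropyl. The position, silent so far across saturated chains only, therefore stays silent when a double bond outside aromatic rings enters the chain and the group changes in size as well. No independent data on the compounds bear on this result, and the series offers no account of it.

Still open is whether this place tolerates any group at all or only plain hydrocarbon chains, since a terminal amine, a carboxylic acid, a hydroxyl, a phenyl ring or a much longer chain has no counterpart among the compounds shown. From the compounds shown here alone, all four compounds also carry the same shared core, so how the numbers in this assay respond to a change elsewhere on that core remains unknown, and these chain steps say nothing about it.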